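Moving One Methoxy Group: An Estimate for Compound 4

This account rests on a few compounds, and the source may have more. Where it says the series, first, only, none or still open, it means among the compounds named here.

These compounds share one core and differ in the aromatic group on the amide nitrogen. In a functional assay on HCT-116 cells (Homo sapiens) for inhibition, read by colorimetric assay, with a stated time of 3 days (a lower number here means a stronger inhibitor, a higher number a weaker inhibitor), compound 3 (`COc1ccccc1NC(=O)CCCCCCNC(=O)C(O)(O)C(F)(F)F`) gives 10100 nM. Compound 2 (`O=C(CCCCCCNC(=O)C(O)(O)C(F)(F)F)Nc1ccc(F)cc1F`) gives 18500 nM, within the scatter of compound 3, and compound 1 (`COc1ccc(OC)c(NC(=O)CCCCCCNC(=O)C(O)(O)C(F)(F)F)c1`) gives 3870 nM. Compound 3 therefore stands level with compound 2, and its number is clearly higher than that of compound 1.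

Compound 4 (`COc1cccc(NC(=O)CCCCCCNC(=O)C(O)(O)C(F)(F)F)c1`) has not been measured. It differs from compound 3 as follows: 3-methoxyphenyl in place of 2-methoxyphenyl on an amide-type nitrogen. In words, 3-methoxyphenyl takes the place of 2-methoxyphenyl on an amide-type nitrogen, so the same atoms are simply joined differently.

Going by the values given here, no measured step makes this exact move, so the evidence is indirect. Exchanging one aromatic group for another gave a 1.8-fold lower number from compound 2 to compound 3 (0.26 log units; within the scatter). Putting hydrogen in place of a methoxy group gave a 2.6-fold higher number from compound 1 to compound 3 (0.42 log units; beyond the scatter), a modest change. Neither step is large, so only a small shift in this assay is expected, leaning slightly towards a lower number. The expected step is a 1.3-fold lower number from compound 3 to compound 4 (0.13 log units; within the scatter). For compound 4 the estimated value is 7500 nM, with an expected range from 3000 nM to 18000 nM.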

Compound 4, half-maximal inhibitory concentration: 6110 nM
Compound 4: the middle estimate sits 1.2-fold (0.09 log units) above what was measured; low and high end bracket the measured number.
By their numbers in this assay, from the lowest: compounds 1, 4, 3 and 2 (each within the scatter of the next, the first and the last beyond it).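

In this assay, going by these compounds alone, 3-methoxyphenyl in place of 2-methoxyphenyl on the amide-type nitrogen gives a 1.7-fold lower number from compound 3 to compound 4 (0.22 log units; within the scatter), so for these two compounds the place of the single methoxy group makes no readable difference. Hydrogen in place of methoxy on an aromatic carbon can now be read twice, as a 2.6-fold higher number from compound 1 to compound 3 (0.42 log units; beyond the scatter) and as a 1.6-fold higher number from compound 1 to compound 4 (0.20 log units; within the scatter), and only the first of these lies beyond the scatter, so losing a methoxy group from compound 1 does not give a clear change in every case. Against the 2,4-difluorophenyl group of compound 2, the 3-methoxyphenyl group gives a 3.0-fold lower number from compound 2 to compound 4 (0.48 log units; beyond the scatter), a modest step beyond the scatter, whereas the 2-methoxyphenyl group gave only a 1.8-fold lower number from compound 2 to compound 3 (0.26 log units; within the scatter), which stays within it.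

Nothing measured here offers an explanation for any of these steps. Still open, as far as these compounds go, is how an aromatic group carrying a nitrile, an amine or a carboxylic acid, or a longer chain in the shared core, would read in this assay, and whether any such change would give a step larger than the modest ones seen so far.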